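This account rests on a few compounds, and the source may have more. Where it says the series, first, only, none or still open, it means among the compounds named here.

Measured compounds:
compound 1 `O=[N+]([O-])c1ccc(CN2CCC(n3cc(CC(OCc4cc(-c5ccccc5)no4)c4ccc(Br)cc4)nn3)CC2)cc1`. In a functional assay on PC-3 cells (Homo sapiens) for cytotoxicity, with a stated time of 48 h (a lower number here means a stronger inhibitor, a higher number a weaker inhibitor), compound 1 gives only a limit, > 25000 nM.
compound 2 `N#Cc1ccc(-c2cc(COC(Cc3cn(C4CCN(Cc5ccc([N+](=O)[O-])cc5)CC4)nn3)c3ccc(Br)cc3)on2)cc1`; compound 2 gives 2000 nM.
compound 3 `O=[N+]([O-])c1ccc(CN2CCC(n3cc(CC(OCc4cc(-c5cccc(F)c5)no4)c4ccc(Br)cc4)nn3)CC2)cc1`; compound 3 gives 9000 nM.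

Compound 3 stands highest of the two numbers given; its nearest neighbour is compound 2, separated by a 4.5-fold higher number from compound 2 to compound 3 (0.65 log units; beyond the scatter). Compound 4 `COc1ccccc1-c1cc(COC(Cc2cn(C3CCN(Cc4ccc([N+](=O)[O-])cc4)CC3)nn2)c2ccc(Br)cc2)on1` is not yet measured; it differs from compound 3 by 2-methoxyphenyl in place of 3-fluorophenyl on an aromatic carbon. Within the data shown here, the steps that bear on this position are an at least 12-fold lower number from compound 1 to compound 2 (1.09 log units; beyond the scatter), an at least 2.7-fold lower number from compound 1 to compound 3 (0.44 log units; beyond the scatter) and a 4.5-fold higher number from compound 2 to compound 3 (0.65 log units; beyond the scatter), all swaps of the aryl substituent on the same ring carbon, two of them starting from the limit of compound 1 (the limit of > 25000 nM in this assay, at which 1 of the 3 values shown sits). Substituent changes here have so far moved the number beyond the scatter in both directions. For compound 4 a step of no change at the digits printed from compound 3 to compound 4 (within the scatter) is expected, with wide uncertainty. Compound 4 is estimated at 9000 nM, between 2500 nM and 25000 nM.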

Compound 4, half-maximal inhibitory concentration: > 25000 nM
Compound 4 gave a limit, no number (the forecaster's own chance of this, stated with the estimate: 25%); middle value at least 2.7-fold (0.44 log units) away from the limit.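

In this assay compound 4 gives only a limit: the limit of > 25000 nM in this assay, at which 2 of the 4 values shown sit.

A substituted phenyl on this ring carbon therefore does not by itself give a readable number: the 2-methoxyphenyl swap brings an at least 2.7-fold higher number from compound 3 to compound 4 (0.44 log units; beyond the scatter) and an at least 12-fold higher number from compound 2 to compound 4 (1.09 log units; beyond the scatter). The step between compound 1 and compound 4 joins two limits and cannot be read.

The compounds shown do not separate the methoxy group itself from where it sits on the phenyl ring. Going by these compounds, how an amine or a carboxylic acid on that phenyl ring would read remains open.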